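Swapping a pyridine for a furan on the shared core

The source may report more compounds than this note shows. Statements on the series, on what has been measured and on what is new or still open speak of the compounds shown alone.

Two compounds measured in a functional assay on HCT-15 cells (Homo sapiens) for cytotoxicity, in the presence of a further agent that is not named here (on this read-out lower numbers stand for stronger inhibition and higher numbers for weaker inhibition), set the scene. Compound 1 `Clc1ccc(-c2cc(-c3ccsc3)nc(-c3ccco3)c2)o1` carries a furan-2-yl group and a thiophen-3-yl group on the shared core. In this assay compound 1 gives > 50000 nM, which is a limit of the assay rather than a number. Compound 2 `Clc1ccc(-c2cc(-c3cccnc3)nc(-c3cccs3)c2)o1` carries a pyridin-3-yl group and a thiophen-2-yl group instead, and in this assay compound 2 gives 1240 nM. Among the numbers shown, compound 2 stands as the only measured value, while the other result is a limit (the limit of > 50000 nM in this assay, at which 1 of the 2 values shown sits).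

Compound 3 `Clc1ccc(-c2cc(-c3ccco3)nc(-c3cccs3)c2)o1` is not yet measured. It differs from compound 2 in one place: furan-2-yl in place of pyridin-3-yl on an aromatic carbon. Compound 3 thus shares its furan-2-yl group with compound 1, whose result sat at the limit, and its thiophen-2-yl group with compound 2. Among the compounds with values here, no measured step links the two groups directly, so the expectation rests on this pairing alone. A step toward weaker inhibition is expected, an 8.1-fold higher number from compound 2 to compound 3 (0.91 log units; beyond the scatter), beyond the usual scatter. For compound 3 the estimate in this assay is 10000 nM, expected to lie between 2500 nM and 50000 nM.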

Compound 3, half-maximal inhibitory concentration: > 50000 nM
Compound 3: only a limit was reported (the forecaster's own chance of this, stated with the estimate: 35%); middle value at least 5.0-fold (0.69 log units) away from the limit.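

At this position the choice of group matters greatly in this assay: with the thiophen-2-yl group kept in place, putting furan-2-yl where pyridin-3-yl stood gives an at least 40-fold higher number from compound 2 to compound 3 (1.60 log units; beyond the scatter). Compound 1 and compound 2 differ in two places, so their gap could not be tied to either group, whereas this single change ties a large loss of inhibition to this one position, even though the two groups have the same counts of hydrogen-bond donors and acceptors. Both compounds with furan-2-yl at this position end at a limit of the assay rather than a number, so the step from compound 1 to compound 3, thiophen-2-yl in place of thiophen-3-yl, cannot be read: the limit of > 50000 nM in this assay, at which 2 of the 3 values shown sit.

The compounds shown leave open whether the nitrogen of pyridin-3-yl is what matters here, which a plain phenyl ring or a pyridin-4-yl group at the same position could begin to test. As far as these compounds go, it also remains open how a dimethylamino group or a longer chain would fare at this position, and what thiophen-3-yl would do when paired with pyridin-3-yl.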